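Exchanging the amine of compound 2's carbamate

The source may hold more compounds than are shown below. What is called first, only, known or untested is meant among the compounds shown, and "the series" means these compounds.

Of the compounds shown here, two with a shared core have been measured in a physicochemical assay, read by spectrophotometry; a higher number here means a weaker inhibitor, a lower number a stronger inhibitor. Compound 1 `CN(C)CCCOc1ccc(-c2cc(=O)c3c(O)c(O)c(O)cc3o2)cc1` gives 231000 nM, and compound 2 `O=C(Oc1ccc(-c2cc(=O)c3c(O)c(O)c(O)cc3o2)cc1)N1CCOCC1` gives 19300 nM, the lower of the two numbers. Compound 3 `CCN(CC)C(=O)Oc1ccc(-c2cc(=O)c3c(O)c(O)c(O)cc3o2)cc1` has diethylamino in place of morpholin-4-yl on a carbonyl carbon. Going by the values given here, the only measured step, a 12-fold lower number from compound 1 to compound 2 (1.08 log units; beyond the scatter), is large, but it exchanges the whole group on the oxygen, whereas here the carbonyl stays, so it bears only loosely on this change. In this assay the expected step, a 1.0-fold lower number from compound 2 to compound 3 (0.01 log units; within the scatter), is therefore none beyond the scatter, in neither direction. For compound 3 the estimate is 19000 nM, with an expected range of 6000 nM to 60000 nM.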

Compound 3, half-maximal inhibitory concentration: 32600 nM
Beside the measured number, compound 3's estimate is 1.7-fold (0.23 log units) below it; low and high end bracket the measured number.
By their numbers in this assay, from the lowest: compounds 2 and 3 (each within the scatter of the next); then compound 1.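

In this assay, the morpholin-4-yl ring is not required to keep the number where it stands on the carbonyl carbon: open-chain diethylamino gives a 1.7-fold higher number from compound 2 to compound 3 (0.23 log units; within the scatter) in that place. The advantage over compound 1 therefore does not rest on morpholin-4-yl alone, as diethylcarbamoyl on the oxygen still gives a 7.1-fold lower number from compound 1 to compound 3 (0.85 log units; beyond the scatter) here. Nothing at hand explains these numbers. From the compounds shown here alone, whether piperidin-1-yl or the longer dipropylamino on the same carbonyl carbon would stay within the scatter of compound 2 remains open.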